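Carboxy in Place of Hydroxymethyl: Expecting Compound 4

The source may report more compounds than this note shows. Statements on the series, on what has been measured and on what is new or still open speak of the compounds shown alone.

Of the compounds shown here, three sharing one core have been tested in an assay on Sf9 cells for inhibition of histone deacetylase 11 (Homo sapiens), read by fluorescence, tested at 0.5 uM; a lower number here means less inhibition, a higher number more inhibition at the concentration tested (going by the name of the read-out). Compound 1 `O=C(/C=C/c1cn([C@@H]2C[C@H](CO)N(CCCc3ccccc3)C2)nn1)NO` gives 12%. Compound 2 `O=C(/C=C/c1cn([C@@H]2C[C@@H](CO)N(CCCc3ccccc3)C2)nn1)NO` gives 13%, the higher of the two numbers shown, though compound 1 sits within the scatter, as a number 1 percentage points higher from compound 1 to compound 2 (within the scatter) shows; that step rests on (the fact that compounds 1 and 2 differ only in the configuration as drawn). Compound 3 `O=C(/C=C/c1cn([C@@H]2C[C@@H](CO)N(Cc3ccccc3)C2)nn1)NO` reports only a limit of the assay, < 10%. The step of a number at least 3 percentage points lower from compound 2 to compound 3 (that floor lies within the scatter) follows phenyl in place of phenethyl on a saturated chain carbon bound to an amine nitrogen in a ring, and the limit of < 10% in this assay, at which 1 of the 3 values shown sits, sets its floor.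

Compound 4 `O=C(/C=C/c1cn([C@@H]2C[C@@H](C(=O)O)N(CCCc3ccccc3)C2)nn1)NO` has not been measured. It differs from compound 2 by carboxy in place of hydroxymethyl on a saturated ring carbon. Among the measured compounds shown here, no measured step touches this group: the step from compound 1 to compound 2 alters only a drawn configuration, and the step from compound 2 to compound 3 alters the chain on the amine nitrogen in the ring. Neither moved beyond the scatter. No change beyond the scatter is therefore expected, and a number 2 percentage points lower from compound 2 to compound 4 (within the scatter) is estimated on that basis. Compound 4 is expected to give 11%, between 4% and 20%.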

Compound 4, a percentage reported as inhibition, at one concentration (the size of the read-out at that concentration, not a potency): < 10%
Compound 4 was reported as a limit; the forecaster's own chance of this, stated with the estimate: 40%; middle value at least 1 percentage points from the limit.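

Compound 4 is the only compound shown that changes the group on this saturated ring carbon, next to the ring nitrogen. In this assay, compound 4 reports only a limit of the assay, < 10%. Placing carboxy where hydroxymethyl stood gives a number at least 3 percentage points lower from compound 2 to compound 4 (that floor lies within the scatter), so this change brings no drop that can be told apart from the scatter, while its true size stays unknown since the floor of the step is set by: the limit of < 10% in this assay, at which 2 of the 4 values shown sit.

The compounds shown leave open whether an amine or a methyl ester on this same ring carbon would read any differently from hydroxymethyl or carboxy. They also leave open whether carboxy would behave alike in the configuration drawn in compound 1, and a reading at one concentration gives no potency for any of them.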